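The source may report more compounds than this note shows. Statements on the series, on what has been measured and on what is new or still open speak of the compounds shown alone.

Compound 3 `Cc1cc(C)cc(C(=O)Nc2cccc(-c3oc4cc(-c5ccc(F)cc5)ccc4c(=O)c3O)c2)c1` stands second highest of the three numbers in a functional assay on HeLa cells (Homo sapiens) for antiproliferative activity, read by CCK-8 assay, with a stated time of 72 h (a lower number here means a stronger inhibitor, a higher number a weaker inhibitor), where compound 3 gives 5540 nM. Compound 1 `COc1ccc(C(=O)Nc2cccc(-c3oc4cc(-c5ccc(F)cc5)ccc4c(=O)c3O)c2)cc1` gives 4820 nM and compound 2 `O=C(Nc1cccc(-c2oc3cc(-c4ccc(F)cc4)ccc3c(=O)c2O)c1)c1ccc(F)cc1F` gives 10700 nM. Of the measured steps, a 2.2-fold higher number from compound 1 to compound 2 (0.35 log units; beyond the scatter) is the only one beyond the scatter, while a 1.1-fold higher number from compound 1 to compound 3 (0.06 log units; within the scatter) and a 1.9-fold lower number from compound 2 to compound 3 (0.29 log units; within the scatter) are not. Compound 4 `N#Cc1ccc(C(=O)Nc2cccc(-c3oc4cc(-c5ccc(F)cc5)ccc4c(=O)c3O)c2)cc1` differs from compound 3 by 4-cyanophenyl in place of 3,5-dimethylphenyl on a carbonyl carbon. Within the data shown here, no measured step swaps in a 4-cyanophenyl, so the expectation rests on the modest spread among compounds 1, 2 and 3 in this assay, and an estimated step of a 1.0-fold lower number from compound 3 to compound 4 (0.00 log units; within the scatter) is expected, with no direction beyond the scatter. Compound 4 is therefore estimated at 5500 nM, within 2500 nM to 12000 nM.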

Compound 4, half-maximal inhibitory concentration: 23300 nM
The estimate for compound 4 lay 4.2-fold (0.63 log units) below the measured number; the whole stated range lies below it.
By their numbers in this assay, from the lowest: compounds 1, 3 and 2 (each within the scatter of the next, the first and the last beyond it); then compound 4.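

Among the groups on this carbonyl carbon, 4-cyanophenyl sets compound 4 apart as the weakest of the four in this assay, beyond the scatter against each of the others (a 4.2-fold higher number from compound 3 to compound 4 (0.62 log units; beyond the scatter); a 2.2-fold higher number from compound 2 to compound 4 (0.34 log units; beyond the scatter)). Among these compounds, the cleanest comparison is the single swap of cyano in place of methoxy on an aromatic carbon (a 4.8-fold higher number from compound 1 to compound 4 (0.68 log units; beyond the scatter)), which shows that one substituent on this ring can shift the number. No evidence here explains this loss. The compounds shown leave open how a 4-chlorophenyl, a 4-aminophenyl or a 4-carboxyphenyl at this position would compare with compound 1 and compound 4.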